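The source may report more compounds than this note shows. Statements on the series, on what has been measured and on what is new or still open speak of the compounds shown alone.

Values in a physicochemical assay for solubility; on this read-out lower numbers stand for lower solubility and higher numbers for higher solubility:
- compound 1 `O=C(CN1CCNCC1)N1CCC(NS(=O)(=O)c2cc(S(=O)(=O)c3ccccc3)ccc2C(F)(F)F)CC1`: 50000 nM
- compound 2 `O=C(Cn1ccnc1)N1CCC(NS(=O)(=O)c2cc(S(=O)(=O)c3ccccc3)ccc2C(F)(F)F)CC1`: 100000 nM
- compound 3 `CC(C)(C)OC(=O)N1CCC[C@H]1C(=O)N1CCC(NS(=O)(=O)c2cc(S(=O)(=O)c3ccccc3)ccc2C(F)(F)F)CC1`: 25000 nM

The standing of compound 3 is set by two steps: a 2.0-fold lower number from compound 1 to compound 3 (0.30 log units; within the scatter), and a 4.0-fold lower number from compound 2 to compound 3 (0.60 log units; beyond the scatter). Compound 4 `CC(C)(C)OC(=O)N1CCC[C@@H]1C(=O)N1CCC(NS(=O)(=O)c2cc(S(=O)(=O)c3ccccc3)ccc2C(F)(F)F)CC1` is the next to be read, and the structural change is this: the two compounds have the same atoms and bonds and differ only in configuration as drawn: 1 of 1 stereo elements differ; a stereocentre at a saturated ring carbon is drawn S in compound 3 and R in compound 4.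

Within the data shown here, no measured step isolates a change of configuration, so the data give no direct precedent. The nearest evidence is the replacement of whole groups on a carbonyl carbon, and these steps are modest at most: a 2.0-fold lower number from compound 1 to compound 3 (0.30 log units; within the scatter), and a 4.0-fold lower number from compound 2 to compound 3 (0.60 log units; beyond the scatter). The change here leaves the atoms and bonds untouched, so no shift beyond the scatter is expected in this assay, and no direction is favoured. The expected step is no change at the digits printed from compound 3 to compound 4 (within the scatter). For compound 4 the estimated value is 25000 nM, with an expected range of 12500 nM to 50000 nM.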

Compound 4, solubility: 25000 nM
Compound 4: the middle estimate sits on the measured number at the digits printed, within the range that was stated.
By their numbers in this assay, from the lowest: compounds 3, 4, 1 and 2 (each within the scatter of the next, the first and the last beyond it).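

In this assay, among these compounds, redrawing the saturated ring carbon from S to R gives no change at the digits printed from compound 3 to compound 4 (within the scatter), the only step that isolates a change of configuration. The group replacements read the same with the R centre as with the S centre: with (1H-imidazol-1-yl)methyl leaving, the step is a 4.0-fold lower number from compound 2 to compound 4 (0.60 log units; beyond the scatter), and with (piperazin-1-yl)methyl leaving, it is a 2.0-fold lower number from compound 1 to compound 4 (0.30 log units; within the scatter), each the same size as the matching step to compound 3. This reading rests on a single pair, whose comparison is confined to one structural feature: the fact that compounds 3 and 4 differ only in the configuration as drawn.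

As far as these compounds go, whether configuration at this carbon stays without effect on the number when the tert-butoxycarbonyl group is replaced by a free secondary amine or the ring carries a carboxylic acid remains open. A stereocentre on a longer chain at the same carbonyl carbon is also untested by the compounds shown.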